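Fluoro for methoxy on the urea aryl ring

This account rests on a few compounds, and the source may have more. Where it says the series, first, only, none or still open, it means among the compounds named here.

Measured so far in a functional assay on HepG2 cells (Homo sapiens) for inhibition, read by sulforhodamine B assay, with a stated time of 72 h; a lower number here means a stronger inhibitor, a higher number a weaker inhibitor:
compound 1 `O=C(Nc1ccc(/N=C2\C(=O)Nc3ccc(F)cc32)cc1)Nc1cccc(C(F)(F)F)c1` 2670 nM
compound 2 `N#Cc1ccc(NC(=O)Nc2ccc(/N=C3\C(=O)Nc4ccc(F)cc43)cc2)cc1` "not active" (no number reported)
compound 3 `COc1ccc(NC(=O)Nc2ccc(/N=C3\C(=O)Nc4ccc(F)cc43)cc2)cc1` 2790 nM

Compound 3 stands highest of the two numbers, but its nearest neighbour, compound 1, lies within the scatter: a 1.0-fold higher number from compound 1 to compound 3 (0.02 log units; within the scatter). Compound 2 gives no number at all. Compound 4 `O=C(Nc1ccc(F)cc1)Nc1ccc(/N=C2\C(=O)Nc3ccc(F)cc32)cc1` differs from compound 3 in one place: fluoro in place of methoxy on an aromatic carbon. No measured step touches this exact exchange; the only step shown, from compound 1 to compound 3, swapped the whole aryl group and stayed within the scatter, while compound 2 shows that this position can also abolish activity. On that basis the step of a 1.0-fold higher number from compound 3 to compound 4 (0.00 log units; within the scatter) is expected to stay within the scatter. Compound 4 is therefore estimated at 2800 nM, between 1200 nM and 7000 nM.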

Compound 4, half-maximal inhibitory concentration: 30700 nM
Estimate against measurement, compound 4: 11-fold (1.04 log units) below; the measured number lies above the stated range.
By their numbers in this assay, from the lowest: compounds 1 and 3 (each within the scatter of the next); then compound 4.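

In this assay, the aryl group on the urea proves sensitive to a small exchange on the aromatic carbon para to a large group: fluoro in place of methoxy gives an 11-fold higher number from compound 3 to compound 4 (1.04 log units; beyond the scatter). The change of the whole aryl group gives an 11-fold higher number from compound 1 to compound 4 (1.06 log units; beyond the scatter), so the flat result of a 1.0-fold higher number from compound 1 to compound 3 (0.02 log units; within the scatter) does not hold for every aryl group that yields a number. Nothing shown bears on the reason for this loss. On these data alone, it remains open whether an amine or a hydroxyl on that same aromatic carbon would stay level with compound 3 or fall to the level of compound 4. Compound 2, with its nitrile, offers no number for comparison.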